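The compounds below may be only part of what the source reports. "The series", "measured", "known", "first", "only" and "open" are said of these compounds alone.

Measured in a functional assay on HepG2 cells (Homo sapiens) for cytotoxicity, read by MTT assay, with a stated time of 48 h; a lower number here means a stronger inhibitor, a higher number a weaker inhibitor:
- compound 1 `CC1=NN(C(=O)CCl)C(c2cc(Br)ccc2O)C1`: 16300 nM
- compound 2 `COc1ccccc1C1CC(C)=NN1C(=O)C[N+]1(C)CCCC1`: 32200 nM
- compound 3 `O=C(c1ccccc1)N1N=C(c2cc3ccccc3oc2=O)CC1c1ccccc1`: 36600 nM

Compound 3 stands within the scatter of compound 2 and beyond the scatter above compound 1. Compound 4 `O=C(CCl)N1N=C(c2cc3ccccc3oc2=O)CC1c1ccccc1` has chloromethyl in place of phenyl on a carbonyl carbon. Among the measured compounds shown here, no measured pair differs in one place only. For the measured compounds named here, compound 1, with a different core, is the only measured compound carrying chloromethyl on a carbonyl carbon, and it gives 16300 nM. On that single comparison, a moderate move towards a lower number is expected in this assay. The expected step is a 2.3-fold lower number from compound 3 to compound 4 (0.36 log units; beyond the scatter). The estimated value for compound 4 is 16000 nM, with an expected range of 6000 nM to 40000 nM.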

Compound 4, half-maximal inhibitory concentration: 2980 nM
For compound 4 the middle estimate is 5.4-fold (0.73 log units) above the measured one; the measured number lies below the stated range.
By their numbers in this assay, from the lowest: compound 4; then compounds 1, 2 and 3 (each within the scatter of the next, the first and the last beyond it).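

On the shared core, the carbonyl carbon on the amide-type ring nitrogen proves sensitive: chloromethyl in place of phenyl gives a 12-fold lower number from compound 3 to compound 4 (1.09 log units; beyond the scatter) in this assay, a large step. Among the compounds shown here, this is the only single-place comparison, so the effect of this change rests on one pair. The change both removes the aromatic ring and brings in chlorine, and this pair cannot separate the two.

Going by these compounds, whether methyl, bromomethyl or aminomethyl at the same carbonyl carbon would keep the lower number remains open. Nothing available bears on the cause of the step.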